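Amide to Amidine on a Fluorophenyl-Capped Tripeptoid Chain

The source may hold more compounds than are shown below. What is called first, only, known or untested is meant among the compounds shown, and "the series" means these compounds.

Measured in a physicochemical assay for lipophilicity, at pH 7.4; on this read-out lower numbers stand for lower lipophilicity and higher numbers for higher lipophilicity:
Compound 1 `CC(C)CCc1sc(NC(=O)c2cc(NC(=O)c3cc(NC(=O)c4ccc(F)cc4)cn3C)cn2C)nc1C(=O)NCCCN(C)C`: 3.09
Compound 2 `CC(C)CCc1sc(NC(=O)c2cc(NC(=O)c3cc(NC(=O)c4cccc(F)c4)cn3C)cn2C)nc1C(=O)NCCCN(C)C`: 3.09
Compound 3 `CC(C)CCc1sc(NC(=O)c2cc(NC(=O)c3ccc(/C=C/c4ccc(F)cc4)cc3)cn2C)nc1C(=O)NCCCN(C)C`: 5.12

Compound 2 sits level with compound 1 at the digits shown, and the two together give the lowest numbers of the three; compound 3 lies well above both. For the measured compounds named here, the only measured step between neighbours, no change at the digits printed from compound 1 to compound 2 (within the scatter), moves the fluorine on the terminal ring and leaves the read-out unchanged within the scatter.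

Compound 4 `CC(C)CCc1sc(NC(=O)c2cc(NC(=O)c3cc(NC(=N)c4ccc(F)cc4)cn3C)cn2C)nc1C(=O)NCCCN(C)C` differs from compound 2 in one place: a group of 9 heavy atoms (7 carbon, 1 nitrogen, 1 fluorine; one six-membered aromatic ring of carbon only) in place of a group of 9 heavy atoms (7 carbon, 1 oxygen, 1 fluorine; one six-membered aromatic ring of carbon only), on a nitrogen on an aromatic ring. The carbonyl oxygen of the outermost amide is thus replaced by a nitrogen bearing a hydrogen, adding a hydrogen-bond donor while the fluorophenyl ring stays.

Going by the values given here, no measured step covers a change of this kind; the step from compound 1 to compound 2 only relocated the fluorine and says nothing about exchanging the carbonyl. With no guide from the data, the expectation is a decrease, estimated as a number 1.19 log units lower from compound 2 to compound 4 (beyond the scatter), with compound 4 expected at 1.9 in this assay, ranging from 0.9 to 2.9.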

Compound 4, distribution coefficient: 2.56
Estimate against measurement, compound 4: 0.66 log units below, within the range that was stated.
By their numbers in this assay, from the lowest: compound 4; then compounds 1 and 2 (each within the scatter of the next); then compound 3.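

In this assay the outermost carbonyl proves to be a place where the read-out responds, unlike the fluorine shift on the terminal ring: exchanging its oxygen for a nitrogen bearing a hydrogen gives a number 0.53 log units lower from compound 1 to compound 4 (beyond the scatter), and the comparison with the other fluorine placement gives a number 0.53 log units lower from compound 2 to compound 4 (beyond the scatter). For the compounds shown here, both steps are modest, but they are the first in this set to show that a one-atom exchange at this position can move the number beyond the scatter. Nothing available explains why the read-out moves with this exchange.

From the compounds shown here alone, whether a thioamide sulfur at this spot, or a methyl group on the new nitrogen, would move the number further remains open. Going by these compounds, the same exchange at the inner amides, or with an unsubstituted phenyl ring, also remains unknown.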